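The compounds below may be only part of what the source reports. "The series", "measured", "known", "first", "only" and "open" are said of these compounds alone.

For the measured compounds named here, the two compounds measured so far share one scaffold and differ only in one aromatic substituent. Compound 1 `O=[N+]([O-])c1ccc(CN2CCC(n3cc(CC(OCc4cc(-c5ccccc5)no4)c4ccc(Br)cc4)nn3)CC2)cc1` gives, in a functional assay on Huh-7 cells (Homo sapiens) for cytotoxicity, with a stated time of 48 h (on this read-out higher numbers stand for weaker inhibition and lower numbers for stronger inhibition), a value of 7000 nM. Compound 2 `COc1ccc(-c2cc(COC(Cc3cn(C4CCN(Cc5ccc([N+](=O)[O-])cc5)CC4)nn3)c3ccc(Br)cc3)on2)cc1` gives in this assay 2000 nM. The step of a 3.5-fold lower number from compound 1 to compound 2 (0.54 log units; beyond the scatter) is the only one recorded, and on these two numbers compound 2 holds the lower one, with compound 1 the nearest neighbour.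

Compound 3 `COc1cccc(-c2cc(COC(Cc3cn(C4CCN(Cc5ccc([N+](=O)[O-])cc5)CC4)nn3)c3ccc(Br)cc3)on2)c1` keeps every atom of compound 2 and differs only in how the methoxy is attached: 3-methoxyphenyl in place of 4-methoxyphenyl on an aromatic carbon. Going by the values given here, no measured step shifts a methoxy within a ring, so the one step recorded speaks only indirectly; it shows that the presence of the methoxy mattered modestly, not how its placement matters. Compound 3 is therefore expected to show a step of a 1.3-fold higher number from compound 2 to compound 3 (0.10 log units; within the scatter), within the scatter, giving an estimate of 2500 nM with a range from 1000 nM to 7000 nM.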

Compound 3, half-maximal inhibitory concentration: 5000 nM
Compound 3: middle estimate off by 2.0-fold (0.30 log units), on the low side, and the stated range covers the measured number.
By their numbers in this assay, from the lowest: compound 2; then compounds 3 and 1 (each within the scatter of the next).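

Moving the methoxy shows that in this assay its placement matters as well as its presence, since 3-methoxyphenyl in place of 4-methoxyphenyl gives a 2.5-fold higher number from compound 2 to compound 3 (0.40 log units; beyond the scatter). Measured against the ring that carries no methoxy, the 3-methoxyphenyl group gives a 1.4-fold lower number from compound 1 to compound 3 (0.15 log units; within the scatter), so among these three compounds only 4-methoxyphenyl stands beyond the scatter of the compound without methoxy. Nothing available here accounts for this dependence on placement.

The compounds shown leave open whether a different group on this aromatic ring, such as a hydroxyl, an amine or a chlorine, would show the same dependence on placement. They also leave open whether the difference between the two methoxyphenyl groups would persist with another group in place of the bromine on the shared core.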